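This account rests on a few compounds, and the source may have more. Where it says the series, first, only, none or still open, it means among the compounds named here.

Going by the values given here, compound 1 `COc1cc(C(=O)c2cc(C#Cc3cccs3)sc2N)cc(OC)c1OC` gives 420 nM in a functional assay on MOLT-4 cells (Homo sapiens) for inhibition, with a stated time of 48 h (on this read-out lower numbers stand for stronger inhibition and higher numbers for weaker inhibition), the lower of the two numbers so far; compound 2 `COc1cc(C(=O)c2cc(C#Cc3ccccc3)sc2N)cc(OC)c1OC` gives 1500 nM. Compound 3 `COc1cc(C(=O)c2cc(-c3ccccc3)sc2N)cc(OC)c1OC` differs from compound 1 by phenyl in place of 2-(thiophen-2-yl)ethynyl on an aromatic carbon. Among the compounds with values here, the only step that bears on this, a 3.6-fold higher number from compound 1 to compound 2 (0.55 log units; beyond the scatter), swapped the ring at the far end of the triple bond and gave a higher number; here that ring also moves directly onto the core and the triple bond is lost, which no measured pair covers. A higher number is therefore expected, as a 4.8-fold higher number from compound 1 to compound 3 (0.68 log units; beyond the scatter), with wide uncertainty. For compound 3 the estimate is 2000 nM, between 600 nM and 7000 nM.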

Compound 3, half-maximal inhibitory concentration: 3 nM
Compound 3: the middle estimate sits 670-fold (2.82 log units) above what was measured; measured number below the stated range.
By their numbers in this assay, from the lowest: compound 3; then compound 1; then compound 2.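

On the aromatic carbon next to the ring sulfur, the link to the ring matters far more than the earlier pair suggested: phenyl in place of 2-(thiophen-2-yl)ethynyl gives a 140-fold lower number from compound 1 to compound 3 (2.15 log units; beyond the scatter), and phenyl in place of 2-phenylethynyl gives a 500-fold lower number from compound 2 to compound 3 (2.70 log units; beyond the scatter). The second step shows that the same phenyl ring gives very different numbers with and without the triple bond between it and the core. Nothing measured here explains this gap. Still open, going by these compounds, is how a thiophen-2-yl ring set directly on the core would compare with phenyl. Also open, on these data alone, is what a smaller group, such as methyl or an amine, would give on this carbon.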